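The source may hold more compounds than are shown below. What is called first, only, known or untested is meant among the compounds shown, and "the series" means these compounds.

In a functional assay on HeLa cells (Homo sapiens) for inhibition, read by MTT assay, with a stated time of 72 h (a lower number here means a stronger inhibitor, a higher number a weaker inhibitor), compound 1 `COc1cc(OC)c(OC)cc1/C=C/C(=O)c1ccc(Cl)cc1` gives 36500 nM. Compound 2 `COc1cc(OC)c(OC)cc1/C=C/C(=O)c1cc(OC(C)=O)ccc1OC(C)=O` gives 57900 nM, and the two values lie within the scatter of each other, so neither stands apart. Compound 3 `COc1ccc(C(=O)/C=C/c2cc(OC)c(OC)cc2OC)cc1` has not yet been measured. It differs from compound 1 by methoxy in place of chloro on an aromatic carbon, para to a large group. Going by the values given here, no measured pair shows such a change, so no step beyond the scatter is expected in this assay, in either direction. The expected step is a 1.1-fold lower number from compound 1 to compound 3 (0.04 log units; within the scatter). Compound 3 is estimated at 33000 nM, with an expected range of 13000 nM to 80000 nM.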

Compound 3, half-maximal inhibitory concentration: 37600 nM
Compound 3: the middle estimate sits 1.1-fold (0.06 log units) below what was measured; low and high end bracket the measured number.
By their numbers in this assay, from the lowest: compounds 1, 3 and 2 (each within the scatter of the next).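

Going from chloro to methoxy on an aromatic carbon, para to a large group, gives a 1.0-fold higher number from compound 1 to compound 3 (0.01 log units; within the scatter) in this assay, and this is the first pair shown that differs in one place. At this position, the 4-chlorophenyl and 4-methoxyphenyl forms therefore cannot be told apart in this assay. No independent measurement bears on this result.

Going by these compounds, whether an amine or a carboxylic acid at this position would also leave the number within the scatter remains open. So does whether the same change would behave alike elsewhere on the shared core.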